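Cyano on the Pyrazole of a Carbamate at the Limit

The source may hold more compounds than are shown below. What is called first, only, known or untested is meant among the compounds shown, and "the series" means these compounds.

Compound 3 `CN(CCN(C)C(c1ccc(OCc2ccccc2)cc1)c1ccc(OCc2ccccc2)cc1)C(=O)n1cccn1` belongs to a small set of carbamates measured in an assay on membranes from brain for binding affinity to Monoglyceride lipase (Mus musculus), read by fluorescence, with stated times of 1 h and 30 min; on this read-out lower numbers stand for stronger inhibition and higher numbers for weaker inhibition. In this assay compound 3 reaches only a limit, > 1000000 nM, and not a number. Compound 2 `Cc1cnn(C(=O)N(C)CCN(C)C(c2ccc(OCc3ccccc3)cc2)c2ccc(OCc3ccccc3)cc2)c1` likewise gives only a limit, > 1000000 nM. For the measured compounds named here, the single change from compound 2 to compound 3, hydrogen in place of methyl on an aromatic carbon, is a step that the two limits leave unreadable from compound 2 to compound 3. Compound 1 `CN(CCN(C)C(=O)n1cccn1)Cc1cccc(OCc2ccccc2)c1`, which carries one benzyloxyphenyl arm rather than two, does give a number in this assay, 4600 nM. Of the three values shown, two sit at the limit of > 1000000 nM in this assay, at which 2 of the 3 values shown sit, and compound 3 is one of them.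

Compound 4 `CN(CCN(C)C(c1ccc(OCc2ccccc2)cc1)c1ccc(OCc2ccccc2)cc1)C(=O)n1cc(C#N)cn1` differs from compound 3 by cyano in place of hydrogen on an aromatic carbon. Going by the values given here, no measured step involves a cyano group, and the only step on the same five-membered ring cannot be read because both of its compounds sit at the limit of > 1000000 nM in this assay, at which 2 of the 3 values shown sit. Among the compounds with values here, the step from compound 3 to compound 4 therefore has no measured precedent of known size, and compound 3 itself offers only a limit as a starting point. Compound 4 is expected to stay weak, with an estimated 500000 nM in a range from 30000 nM to 2000000 nM, which would mean an expected step of an at least 2.0-fold lower number from compound 3 to compound 4 (0.30 log units; that floor lies within the scatter).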

Compound 4, half-maximal inhibitory concentration: 32000 nM
Beside the measured number, compound 4's estimate is 16-fold (1.19 log units) above it; the range from low to high includes it.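

The change to 4-cyano-1H-pyrazol-1-yl gives an at least 31-fold lower number from compound 3 to compound 4 (1.49 log units; beyond the scatter), so in this assay a substituent on this aromatic carbon, two ring bonds from the ring nitrogen, can bring a compound with two benzyloxyphenyl arms off the limit and onto a number. Set against methyl on the same carbon, cyano gives an at least 31-fold lower number from compound 2 to compound 4 (1.49 log units; beyond the scatter), which shows that the two groups are not interchangeable at this place, something the unreadable step between the methyl and hydrogen compounds could not show. Both steps are floors and not full sizes because compound 2 and compound 3 share a value that is only a limit: the limit of > 1000000 nM in this assay, at which 2 of the 4 values shown sit.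

The compounds shown leave open whether the nitrile itself is needed at this place, or whether another group, such as a chlorine atom, an amide or a carboxylic acid, would do the same. They also leave open what cyano would do in the core of compound 1, which carries one benzyloxyphenyl arm and gives 4600 nM with the unsubstituted 1H-pyrazol-1-yl group.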